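Replacing the amide substituent of compound 1 with propyl

This account rests on a few compounds, and the source may have more. Where it says the series, first, only, none or still open, it means among the compounds named here.

Measured so far in a functional assay on HepG2 cells (Homo sapiens) for antiproliferative activity, read by MTT assay; on this read-out lower numbers stand for stronger inhibition and higher numbers for weaker inhibition:
compound 1 `Nc1c(C(=O)N/N=C/c2ccccc2)oc2nc(-c3ccccc3)cc(C(F)(F)F)c12` gives 13100 nM
compound 2 `Nc1c(C(=O)N/N=C/c2ccccc2)oc2nc(-c3cccs3)cc(C(F)(F)F)c12` gives 9900 nM
compound 3 `CCNC(=O)c1oc2nc(-c3cccs3)cc(C(F)(F)F)c2c1N` gives 12100 nM

Compound 1 at 13100 nM is not separated from the other two compounds. Its gaps to compound 2 and compound 3 lie within the scatter, so the three values form one group.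

Compound 4 `CCCNC(=O)c1oc2nc(-c3ccccc3)cc(C(F)(F)F)c2c1N` has not been measured. Its change from compound 1 is a group of 3 heavy atoms (3 carbon; no ring) in place of a group of 8 heavy atoms (7 carbon, 1 nitrogen; one six-membered aromatic ring of carbon only), on an amide-type nitrogen, and the entering group is propyl. The phenyl of compound 1 stays in place.

The closest measured change on that nitrogen is a 1.2-fold higher number from compound 2 to compound 3 (0.09 log units; within the scatter). It lies within the scatter, but it was seen with thiophen-2-yl in place of phenyl. That aryl swap, a 1.3-fold lower number from compound 1 to compound 2 (0.12 log units; within the scatter), also lies within the scatter. Among the compounds with values here, no propyl compound has been measured, so the comparison rests on a single change at the nitrogen.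

No step beyond the scatter is expected in this assay, and the estimated 1.1-fold lower number from compound 1 to compound 4 (0.04 log units; within the scatter) stays within it. The estimate for compound 4 is 12000 nM, with an expected range from 5500 nM to 26000 nM.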

Compound 4, half-maximal inhibitory concentration: 37400 nM
For compound 4 the middle estimate is 3.1-fold (0.49 log units) below the measured one; measured number outside the range, above it.
By their numbers in this assay, from the lowest: compounds 2, 3 and 1 (each within the scatter of the next); then compound 4.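

In this assay, within the data shown here, the amide-type nitrogen now gives the first change to pass the scatter, with a 2.9-fold higher number from compound 1 to compound 4 (0.46 log units; beyond the scatter) as propyl replaces the group on that nitrogen and phenyl stays in place. The earlier change on this nitrogen, a 1.2-fold higher number from compound 2 to compound 3 (0.09 log units; within the scatter) and within the scatter, had a different entering group and thiophen-2-yl on the core, so the substituent on this nitrogen cannot be treated as silent in every setting, and the two steps cannot separate the effect of the chain from that of the aryl group. No measurement available here bears on the reason for this step.

From the compounds shown here alone, whether propyl gives a similar step with thiophen-2-yl in place of phenyl, and where ethyl falls with phenyl kept, remains open. Also open, going by these compounds, is how a longer chain such as butyl, or a chain ending in an amine or a carboxylic acid, would read in this assay on this nitrogen.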